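Replacing an amine arm with an amide on the macrocycle

This account rests on a few compounds, and the source may have more. Where it says the series, first, only, none or still open, it means among the compounds named here.

Compound 1 `CC(C)=CCC[C@]1(C)/C=C/[C@@H](OC(=O)C=C(C)C)[C@](C)(O)/C=C/C(=O)/C(CN(C(C)C)C(C)C)=C\C1` and compound 2 `CC(C)=CCC[C@](C)(/C=C/[C@@H](OC(=O)C=C(C)C)[C@](C)(O)/C=C/C(=O)/C=C/N1CCN(C)CC1)CC=O` share a core and were tested in a functional assay on HL-60 cells (Homo sapiens) for antiproliferative activity, read by MTT assay, with a stated time of 48 h; on this read-out higher numbers stand for weaker inhibition and lower numbers for stronger inhibition. Compound 1 gives 740 nM, and compound 2 gives 1060 nM; the number for compound 1 is the lower of the two, yet the gap lies within the scatter, so neither can be set above the other. Compound 3 `CC(C)=CCC[C@]1(C)/C=C/[C@@H](OC(=O)C=C(C)C)[C@](C)(O)/C=C/C(=O)/C(C(=O)N(C(C)C)C(C)C)=C\C1` differs from compound 1 by diisopropylcarbamoyl in place of (diisopropylamino)methyl on a double-bonded ring carbon. For the measured compounds named here, no comparable step has been measured, so the expectation rests on the change alone: compound 3 is expected to show a modest weakening, with a 1.8-fold higher number from compound 1 to compound 3 (0.24 log units; within the scatter), giving an estimate of 1300 nM within a range of 400 nM to 4000 nM.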

Compound 3, half-maximal inhibitory concentration: 12700 nM
The estimate for compound 3 lay 9.8-fold (0.99 log units) below the measured number; measured number above the stated range.
By their numbers in this assay, from the lowest: compounds 1 and 2 (each within the scatter of the next); then compound 3.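

On the double-bonded ring carbon, diisopropylcarbamoyl in place of (diisopropylamino)methyl is far from a neutral exchange: in this assay it brings a large weakening, a 17-fold higher number from compound 1 to compound 3 (1.23 log units; beyond the scatter). Compound 1 and compound 2 differ in more than one place and could not isolate this position, whereas this single change moves the number well beyond the scatter. Nothing available bears on why the number rises. The compounds shown leave open whether the carbonyl itself or the whole diisopropylcarbamoyl group governs this loss. As far as these compounds go, how a morpholin-4-ylmethyl arm or a carboxylic acid would fare on this ring carbon also remains open.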